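A few compounds are considered here, and "the series" means these few. Any claim that something is new, unique, unknown or untested is made for them only; others in the source may bear on it.

Two measured compounds set the level here. In an ADME assay on microsomes from liver (Homo sapiens) for metabolic stability, with a stated time of 10 min (on this read-out higher numbers stand for a more stable compound and lower numbers for a less stable compound), compound 1 (`COc1cc(C)c(Nc2nc(Cl)cn([C@H](C)C3CC3)c2=O)c(C)n1`) gives 81%. Compound 2 (`COc1nc(C)c(Nc2nc(Cl)cn([C@H](C)C3CC3)c2=O)c(OC)n1`) gives 81% in this assay, which places compound 2 level with compound 1 within the usual scatter. Compound 3 (`COC[C@H](C1CC1)n1cc(Cl)nc(Nc2c(C)nc(OC)nc2OC)c1=O`) has not yet been measured. It differs from compound 2 in one place: methoxy in place of hydrogen on a saturated chain carbon, two bonds along the chain from an aromatic nitrogen and a saturated ring carbon. This is methoxy in place of hydrogen on a saturated chain carbon, so 1-cyclopropylethyl becomes 1-cyclopropyl-2-methoxyethyl. Within the data shown here, no measured pair shows this change, so the expectation is a judgment and not a reading from a matched step. A small fall in this assay is expected, possibly none beyond the scatter. The expected size of the step is a number 6 percentage points lower from compound 2 to compound 3 (within the scatter). For compound 3 the estimated value is 75%, with an expected range from 58% to 90%.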

Compound 3, percent of the compound remaining: 18%
Estimate against measurement, compound 3: 57 percentage points above; the whole stated range lies above it.
By their numbers in this assay, from the lowest: compound 3; then compounds 1 and 2 (each within the scatter of the next).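

Compounds 1 and 2 both carry 1-cyclopropylethyl, so they said nothing about how this assay responds to a change on this saturated chain carbon. Compound 3 shows that the position is far from indifferent: going from 1-cyclopropylethyl to 1-cyclopropyl-2-methoxyethyl, a change of only 2 heavy atoms, gives a number 63 percentage points lower from compound 2 to compound 3 (beyond the scatter). Nothing measured here speaks to the reason for a step of this size.

From the compounds shown here alone, it remains open whether this fall belongs to the methoxy group itself or to any substituent on that carbon, since a hydroxy group, a fluorine atom or a longer chain such as ethoxymethyl could read differently at the same place. Going by these compounds, it is equally open whether the same change would produce a step of similar size on the core of compound 1.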